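The source may report more compounds than this note shows. Statements on the series, on what has been measured and on what is new or still open speak of the compounds shown alone.

In an ADME assay on MT4 cells (Homo sapiens) for cytotoxicity, read by MTT assay, with a stated time of 4 days (a higher number here means that more compound is tolerated, a lower number that less compound is tolerated), all three measured compounds are tolerated at high concentration. Compound 1 (`CCCN(CCC)c1nc(Cc2c(F)cccc2F)cc(=O)[nH]1`) reaches only a limit, > 78000 nM. Compound 2 (`Cc1c(Cc2c(F)cccc2F)nc(N(C)C(C)C)[nH]c1=O`) gives a true number, 79000 nM. Compound 3 (`Cc1c(C(C)c2c(F)cccc2F)nc(N(C)C(C)C)[nH]c1=O`) again reaches only a limit, > 81000 nM, so it has no exact place on the scale.

Within the data shown here, the one measured step is an at least 1.0-fold higher number from compound 2 to compound 3 (0.01 log units; that floor lies within the scatter), made by methyl in place of hydrogen on a saturated chain carbon bound to two aromatic carbons. Compound 4 (`Cc1c(C(C)c2c(F)cccc2F)nc(N2CCC(C)CC2)[nH]c1=O`) keeps that methyl but changes the amino group, with 4-methylpiperidin-1-yl in place of isopropyl(methyl)amino on an aromatic carbon. The measured step does not touch this carbon, so it bears on the change only indirectly. Compound 1 and compound 2 do carry different amino groups there, though they differ elsewhere too, and their results lie close together.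

In this assay, among the measured compounds shown here, no step clearly beyond the scatter is therefore expected, only a slight lean towards a lower number. The value expected for compound 4 is 60000 nM, estimated to lie between 25000 nM and 100000 nM. This expected value means an at least 1.3-fold lower number from compound 3 to compound 4 (0.13 log units; that floor lies within the scatter).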

Compound 4, half-maximal cytotoxic concentration: 54000 nM
For compound 4 the middle estimate is 1.1-fold (0.05 log units) above the measured one; low and high end bracket the measured number.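

For the first time among these compounds, the amino group on the aromatic carbon between two ring nitrogen atoms changes while everything else stays the same: in this assay, 4-methylpiperidin-1-yl in place of isopropyl(methyl)amino gives an at least 1.5-fold lower number from compound 3 to compound 4 (0.17 log units; that floor lies within the scatter). That step is only a floor and its true size stays unknown, because the value of compound 3 is a limit and not a number: the limit of > 81000 nM in this assay, at which 1 of the 4 values shown sits.

Compound 4 gives 54000 nM, so a six-membered non-aromatic ring at this place, larger in heavy atoms than the group it replaces, still leaves a compound tolerated at high concentration, and the series with the methyl on the chain carbon now has an exact value.

Still open, going by these compounds, is whether piperidin-1-yl without the methyl, or morpholin-4-yl, would give a value in the same range on the same carbon in this assay. Also open, on these data alone, is whether 4-methylpiperidin-1-yl would give a step of similar size in a compound without the methyl on the chain carbon, such as compound 2.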